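Swapping an aryl group for a furan on a fused core

A few compounds are considered here, and "the series" means these few. Any claim that something is new, unique, unknown or untested is made for them only; others in the source may bear on it.

Of the compounds shown here, two have been tested so far in a functional assay on the whole organism (strain Wistar albino) for inhibition, with Rattus norvegicus as the target, read by paw edema, with stated times of 30 min and 3 h, at a dose of 20 mg/kg by the oral route; on this read-out lower numbers stand for less inhibition and higher numbers for more inhibition at the one dose given (going by the name of the read-out). Compound 1, `CCCc1nn2c(C(C)c3ccc(CC(C)C)cc3)nnc2s1`, carries a propyl chain on its fused core and gives 34% in this assay. Compound 2, `CC(C)Cc1ccc(C(C)c2nnc3sc(-c4ccccc4Cl)nn23)cc1`, gives 59% in this assay and so stands highest of the two numbers, with compound 1 the nearest and lower. Among the measured compounds shown here, the one measured step, a number 25 percentage points higher from compound 1 to compound 2 (beyond the scatter), shows that replacing a short chain with an aromatic ring at this position raised the read-out beyond the scatter.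

Compound 3, `CC(C)Cc1ccc(C(C)c2nnc3sc(-c4ccco4)nn23)cc1`, has not yet been measured. It differs from compound 2 as follows: furan-2-yl in place of 2-chlorophenyl on an aromatic carbon. For the measured compounds named here, no measured step compares one aromatic ring with another at this position, so the only guide is that both compound 2 and compound 3 carry an aromatic ring where compound 1 carries propyl. On that basis the step of a number 9 percentage points lower from compound 2 to compound 3 (within the scatter) is expected to be small, most likely a modest decline that may stay within the scatter. Compound 3 is therefore estimated to give 50% in this assay, within a range from 35% to 65%.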

Compound 3, a percentage reported as inhibition, in the whole organism at one dose (the size of the read-out at that dose, not a potency): 64%
Compound 3: the middle estimate sits 14 percentage points below what was measured, and the stated range covers the measured number.
By their numbers in this assay, from the lowest: compound 1; then compounds 2 and 3 (each within the scatter of the next).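

Exchanging 2-chlorophenyl for furan-2-yl gives a number 5 percentage points higher from compound 2 to compound 3 (within the scatter) in this assay, so on this aromatic carbon, next to the ring sulfur, a five-membered aromatic ring with an oxygen cannot be told apart from a six-membered carbon ring bearing chlorine. Exchanging the propyl chain for furan-2-yl gives a number 30 percentage points higher from compound 1 to compound 3 (beyond the scatter), so a second, quite different aromatic ring repeats the rise first seen with 2-chlorophenyl, and among these three compounds both aromatic rings stand clear of the chain, with no compound going against that pattern. Nothing measured on these compounds explains why the two rings read alike or why either differs from propyl.

Among the compounds shown here, with only two rings and one chain, it remains open whether an aromatic ring is needed at all, since a cyclohexyl ring or a longer chain such as hexyl would test that directly. Going by these compounds, it is also open whether the chlorine contributes anything to the reading of 2-chlorophenyl, and whether the oxygen matters in furan-2-yl, questions that a plain phenyl ring and a thiophene ring could address.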